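The source may report more compounds than this note shows. Statements on the series, on what has been measured and on what is new or still open speak of the compounds shown alone.

Notes on the aryl variation on the shared core of compound 1 `COc1nc(N)nc2c1c(-c1cc3ccccc3o1)cn2[C@@H]1O[C@H](CO)[C@@H](O)[C@H]1O`. In a functional assay on K562 cells (Homo sapiens), read by MTT assay, with a stated time of 72 h (on this read-out higher numbers stand for weaker inhibition and lower numbers for stronger inhibition), compound 1 gives 15500 nM. Compound 2 `COc1nc(N)nc2c1c(-c1ccccc1)cn2[C@@H]1O[C@H](CO)[C@@H](O)[C@H]1O` carries phenyl in place of 1-benzofuran-2-yl on the same aromatic carbon. In this assay compound 2 gives only > 20000 nM, a limit of the assay and not a number. Compound 3 `COc1nc(N)nc2c1c(-c1ccoc1)cn2[C@@H]1O[C@H](CO)[C@@H](O)[C@H]1O` carries furan-3-yl at that carbon. In this assay compound 3 likewise gives only > 20000 nM, again a limit rather than a number. The measured steps are therefore an at least 1.2-fold higher number from compound 1 to compound 2 (0.11 log units; that floor lies within the scatter) and an at least 1.2-fold higher number from compound 1 to compound 3 (0.11 log units; that floor lies within the scatter), while a step that the two limits leave unreadable from compound 2 to compound 3. Compound 3 thus stands at the limit of > 20000 nM in this assay, at which 2 of the 3 values shown sit, with one other value sharing that position. Compound 4 `COc1nc(N)nc2c1c(-c1ccsc1)cn2[C@@H]1O[C@H](CO)[C@@H](O)[C@H]1O` differs from compound 3 by thiophen-3-yl in place of furan-3-yl on an aromatic carbon. Among the measured compounds shown here, no measured step exchanges one five-membered aromatic ring with 1 hetero atom for another, and the steps from compound 1 are floors only, so no size beyond the scatter can be read from them. The step that the limit leaves unreadable from compound 3 to compound 4 is expected to lie within the scatter. For compound 4 the expected value in this assay is 22000 nM, range 8000 nM to 60000 nM, most likely reported again as a limit.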

Compound 4, half-maximal inhibitory concentration: > 20000 nM
Compound 4 was reported as a limit; the forecaster's own chance of this, stated with the estimate: 60%; the middle value lies beyond the limit too.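

In this assay compound 4 gives > 20000 nM, a limit of the assay and not a number. Against compound 1 there is an at least 1.2-fold higher number from compound 1 to compound 4 (0.11 log units; that floor lies within the scatter), while the steps linking compound 4 to compound 2 and compound 3 cannot be read. Exchanging furan-3-yl for thiophen-3-yl, with oxygen giving way to sulfur in a ring of the same size, therefore yields no number and adds a third group to the same reading: the limit of > 20000 nM in this assay, at which 3 of the 4 values shown sit.

Among the compounds shown here, compound 1, with 1-benzofuran-2-yl, is the only compound here with a number, and the data do not show whether it is separated from the others beyond the scatter. As far as these compounds go, it also remains open how this assay would read with a carboxylic acid or an aminomethyl group on the aryl ring at this carbon.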